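Swapping iodine for a phenyltriazole on a fluorinated hydroxamate

The source may hold more compounds than are shown below. What is called first, only, known or untested is meant among the compounds shown, and "the series" means these compounds.

Measured so far:
compound 1 `CC(=O)Nc1ccc(NC(=O)C(F)(F)C(F)(F)C(F)(F)C(F)(F)C(F)(F)C(F)(F)C(=O)NO)cc1`, 36000 nM
compound 2 `O=C(NO)C(F)(F)C(F)(F)C(F)(F)C(F)(F)C(F)(F)C(F)(F)C(=O)Nc1ccc(I)cc1`, 36000 nM

Among the compounds with values here, in an assay on isolated protein for inhibition of histone deacetylase 8 (Homo sapiens), read by fluorescence (on this read-out higher numbers stand for weaker binding and lower numbers for tighter binding), compound 2 gives 36000 nM, level with compound 1, and the single measured step was no change at the digits printed from compound 1 to compound 2 (within the scatter). Compound 3 `O=C(NO)C(F)(F)C(F)(F)C(F)(F)C(F)(F)C(F)(F)C(F)(F)C(=O)Nc1ccc(-c2cn(-c3ccccc3)nn2)cc1` arises from compound 2 by 1-phenyl-1H-1,2,3-triazol-4-yl in place of iodo on an aromatic carbon. Within the data shown here, the only step at hand changed the group on the same aromatic carbon without effect, so no firm direction can be read from it; a step of modest size is expected, a 1.8-fold lower number from compound 2 to compound 3 (0.26 log units; within the scatter). Compound 3 is therefore estimated at 20000 nM, with a range from 5000 nM to 80000 nM.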

Compound 3, dissociation constant: > 100000 nM
Compound 3: no number, only a limit; the forecaster's own chance of this, stated with the estimate: 10%; middle value at least 5.0-fold (0.69 log units) away from the limit.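

In this assay, this aromatic carbon is not indifferent to its group: iodo and acetamido read alike, but the 1-phenyl-1H-1,2,3-triazol-4-yl group gives an at least 2.7-fold higher number from compound 2 to compound 3 (0.44 log units; beyond the scatter) and also an at least 2.7-fold higher number from compound 1 to compound 3 (0.44 log units; beyond the scatter). So a change here can weaken binding beyond the scatter. Compound 3 gives no number, only a limit of the assay: the limit of > 100000 nM in this assay, at which 1 of the 3 values shown sits.

From the compounds shown here alone, it stays open whether the triazole ring or the outer phenyl ring carries the loss, which a plain phenyl on this carbon could help separate. Whether an amine or a carboxylic acid here would tighten binding is also unknown.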